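Bromo to Chloro on the Pendant Phenyl Ring

A few compounds are considered here, and "the series" means these few. Any claim that something is new, unique, unknown or untested is made for them only; others in the source may bear on it.

Measured compounds:
- compound 1, `N#Cc1cc(-c2ccccc2)n(-c2ccc(Br)cc2)c1N`: 4600 nM
- compound 2, `N#Cc1cc(-c2ccccc2)n(-c2ccc(Cl)cc2)c1N`: 7700 nM
- compound 3, `Nc1c(-c2nc3ccccc3[nH]2)cc(-c2ccccc2)n1-c1cccc(Br)c1`: 13500 nM

In a functional assay on A549 cells (Homo sapiens) for cytotoxicity, read by resazurin assay, with a stated time of 72 h (on this read-out lower numbers stand for stronger inhibition and higher numbers for weaker inhibition), compound 1 gives 4600 nM, and compound 2, which carries chloro in place of bromo on an aromatic carbon, gives 7700 nM; the step of a 1.7-fold higher number from compound 1 to compound 2 (0.22 log units; within the scatter) lies within the scatter. Compound 3 belongs to a second core; the difference between the two cores is not broken down here. In this assay compound 3 gives 13500 nM, which is within the scatter of compound 2.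

Compound 4, `Nc1c(-c2nc3ccccc3[nH]2)cc(-c2ccccc2)n1-c1cccc(Cl)c1`, is not yet measured. It carries chloro in place of bromo on an aromatic carbon. This is the same kind of change as from compound 1 to compound 2, but the place differs: there the chloro sat para to a large group, here it sits meta to a large group. Because a 1.7-fold higher number from compound 1 to compound 2 (0.22 log units; within the scatter) was small, a similarly small step is expected, a 1.3-fold higher number from compound 3 to compound 4 (0.12 log units; within the scatter). Compound 4 is therefore estimated at 18000 nM, between 8000 nM and 40000 nM.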

Compound 4, half-maximal inhibitory concentration: 7000 nM
The estimate for compound 4 lay 2.6-fold (0.41 log units) above the measured number, outside the stated range (below it).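

In this assay, chloro in place of bromo gives a 1.9-fold lower number from compound 3 to compound 4 (0.29 log units; within the scatter) and so, on this core, the swap alone cannot be told apart from the noise of repeat measurements. Each step is small on its own, but set side by side they do differ, so the step seen on one core cannot simply be carried over to the other: the same change on two cores in this assay, a 1.7-fold higher number (0.22 log units; within the scatter) from compound 1 to compound 2 and a 1.9-fold lower number (0.29 log units; within the scatter) from compound 3 to compound 4, 3.2-fold (0.51 log units) apart, beyond the scatter of two such steps. This rests on a single pair per core and does not show why the steps differ, or whether the gap comes from the core itself or from where the halogen sits.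

The compounds shown carry only bromo and chloro on this phenyl ring. Going by these compounds, how a fluoro, a methoxy group or an amine in that place would read on either core remains open.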